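The compounds below may be only part of what the source reports. "The series", "measured", "known", "first", "only" and "open" are said of these compounds alone.

Working notes on the series: in an ADME assay on HEK-293T cells (Homo sapiens) for inhibition, read by CCK-8 assay, with a stated time of 48 h, tested at 20 uM (a higher number here means more inhibition of growth at the concentration tested, a lower number less inhibition of growth), compound 1 (`Cc1ccc(S(=O)(=O)Oc2ccccc2/C=C(\C#N)C(=O)Nc2nnc(C)s2)cc1`) gives 35% while compound 2 (`N#C/C(=C\c1ccccc1OS(=O)(=O)c1ccc(Cl)cc1)C(=O)Nc1nnc(Cc2cccc3ccccc23)s1`) gives 16% and compound 3 (`Cc1ccc(S(=O)(=O)Oc2ccccc2/C=C(\C#N)C(=O)Nc2nnc(Cc3ccccc3)s2)cc1`) gives 15% on the same read-out. Compound 3 matches compound 2 within the scatter, and its gap to compound 1 lies beyond the scatter. Compound 4 (`N#C/C(=C\c1ccccc1OS(=O)(=O)c1ccc(Cl)cc1)C(=O)Nc1nnc(Cc2ccccc2)s1`) carries chloro in place of methyl on an aromatic carbon, para to a large group (chloro in place of methyl on an aromatic carbon), with the rest of compound 3 unchanged. Among the measured compounds shown here, the one measured step, a number 20 percentage points lower from compound 1 to compound 3 (beyond the scatter), sits at a different place in the structure and does not test this change. Compound 2 carries the (4-chlorophenyl)sulfonyl group and gives 16% in this assay together with a further difference elsewhere, so it offers only a loose hint that chloro at this place need not move the number. No change beyond the scatter is expected, and the estimated step of a number 1 percentage points higher from compound 3 to compound 4 (within the scatter) is small. Compound 4 is estimated at 16% (expected range 4% to 30%).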

Compound 4, percent growth inhibition at one concentration: 25%
Compound 4: the middle estimate sits 9 percentage points below what was measured, within the range that was stated.
By their numbers in this assay, from the lowest: compounds 3, 2, 4 and 1 (each within the scatter of the next, the first and the last beyond it).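

In this assay, the direct exchange of methyl for chloro on an aromatic carbon, para to a large group, turning (4-methylphenyl)sulfonyl into (4-chlorophenyl)sulfonyl, gives a number 10 percentage points higher from compound 3 to compound 4 (within the scatter) and so shows no step beyond the scatter at this position. With the (4-chlorophenyl)sulfonyl group held constant, phenyl in place of naphthalen-1-yl gives a number 9 percentage points higher from compound 2 to compound 4 (within the scatter) and also stays within the scatter, which turns the earlier loose hint from compound 2 into two matched comparisons. No measurement bearing on the origin of either step is available.

From the compounds shown here alone, whether a methoxy group, an amine or a carboxylic acid at this aromatic carbon would also stay within the scatter remains open. So does whether chloro in place of methyl gives a similar step on the core of compound 1.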